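Butoxy in Place of Dimethylamino: Expected Shift

The compounds below may be only part of what the source reports. "The series", "measured", "known", "first", "only" and "open" are said of these compounds alone.

Compound 3 `COc1ccc(Nc2nccc(-c3sc(N(C)C)nc3C)n2)c(OC)c1` gives the lowest number of the three measured compounds in a functional assay on MV4-11 cells (Homo sapiens) for inhibition, read by resazurin assay, with a stated time of 72 h (a lower number here means a stronger inhibitor of growth, a higher number a weaker inhibitor of growth), namely 170 nM. Its nearest neighbour is compound 2 `COc1ccc(Nc2nccc(-c3sc(SCc4cccnc4)nc3C)n2)c(OC)c1`, which in this assay gives 270 nM; the step of a 1.6-fold lower number from compound 2 to compound 3 (0.20 log units; within the scatter) lies within the scatter. Far behind stands compound 1 `CCSc1nc(C)c(-c2ccnc(Nc3ccc(OC)cc3OC)n2)s1`, which in this assay gives 32400 nM, so that a 190-fold lower number from compound 1 to compound 3 (2.28 log units; beyond the scatter) and a 120-fold lower number from compound 1 to compound 2 (2.08 log units; beyond the scatter) are both large.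

Compound 4 `CCCCOc1nc(C)c(-c2ccnc(Nc3ccc(OC)cc3OC)n2)s1` differs from compound 3 in one place: butoxy in place of dimethylamino on an aromatic carbon. Among the measured compounds shown here, two measured steps bear on this change. The step of a 190-fold lower number from compound 1 to compound 3 (2.28 log units; beyond the scatter) shows that moving from ethylsulfanyl to dimethylamino on the aromatic carbon lowered the number greatly; compound 4 runs the other way, from dimethylamino to butoxy, another chain without a ring. The step of a 1.6-fold lower number from compound 2 to compound 3 (0.20 log units; within the scatter) shows that the sulfur-linked group carrying a ring gave a number close to that of dimethylamino, but butoxy has no ring. The expectation is therefore a clear rise in the number, a step of about a 24-fold higher number from compound 3 to compound 4 (1.37 log units; beyond the scatter), while the gap between a chain on sulfur and a chain on oxygen is not measured here, so the range is wide. Compound 4 is estimated at 4000 nM, between 600 nM and 25000 nM.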

Compound 4, concentration for 50% growth inhibition: 7860 nM
Estimate against measurement, compound 4: 2.0-fold (0.29 log units) below, and the stated range covers the measured number.
By their numbers in this assay, from the lowest: compounds 3 and 2 (each within the scatter of the next); then compound 4; then compound 1.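

Against this assay this is the first oxygen-linked chain at this aromatic carbon, and it falls well short of both nitrogen-linked dimethylamino and the ring-bearing sulfur group: the change gives a 46-fold higher number from compound 3 to compound 4 (1.66 log units; beyond the scatter) and also a 29-fold higher number from compound 2 to compound 4 (1.46 log units; beyond the scatter), both large steps. The chain without a ring on oxygen nevertheless does better than the short chain on sulfur, with a 4.1-fold lower number from compound 1 to compound 4 (0.62 log units; beyond the scatter), a modest step that places compound 4 clearly apart from both ends of the series and shows that a ringless chain at this carbon need not give a number as high as that of compound 1. Nothing among the available data accounts for these differences.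

As far as these compounds go, what an ethoxy or a butylsulfanyl group would give at this carbon remains open, and with it whether the linking atom or the chain length carries the gap between ethylsulfanyl and butoxy. Also open, from the compounds shown here alone, is whether a (pyridin-3-yl)methoxy group would match the ring-bearing sulfur group, and whether a longer dialkylamine or a cyclic amine such as morpholine would hold the level of dimethylamino.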